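This account rests on a few compounds, and the source may have more. Where it says the series, first, only, none or still open, it means among the compounds named here.

Of the compounds shown here, three built on one shared core have been tested in a functional assay on the whole organism (strain Swiss) with Mus musculus as the target, in the maximal electroshock model, with a stated time of 1 h, at a dose of 100 mg/kg by the intraperitoneal route; a higher number here means a stronger effect of the compound at the dose given, a lower number a weaker effect. Compound 1 `CC(C(=O)N1CCN(c2ccc(Cl)cc2)CC1)N1C(=O)CCC1=O` gives 0%. Compound 2 `CCC(C(=O)N1CCN(c2cccc(F)c2)CC1)N1C(=O)CCC1=O` gives 0%, level with compound 1 at the digits shown, and together these two are the lowest of the three. Compound 3 `CC(C(=O)N1CCN(c2ccccc2C(F)(F)F)CC1)N1C(=O)CCC1=O` gives 25%, a reading beyond the scatter above compound 2. Compound 4 `CCC(C(=O)N1CCN(c2cccc(Cl)c2)CC1)N1C(=O)CCC1=O` has not yet been measured. It differs from compound 2 in one place: chloro in place of fluoro on an aromatic carbon. Going by the values given here, no measured pair differs by this change alone, so there is no direct guide to its effect. The step of a number 5 percentage points higher from compound 2 to compound 4 (within the scatter) is expected to be small, with no clear direction beyond the scatter. Compound 4 is therefore expected to give about 5%, within a range from 0% to 25%.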

Compound 4, a percentage reported as activity, at one dose (the size of the read-out at that dose, not a potency): 0%
Beside the measured number, compound 4's estimate is 5 percentage points above it; measured number inside the range.
By their numbers in this assay, from the lowest: compounds 1, 2 and 4 (each within the scatter of the next); then compound 3.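

Chloro in place of fluoro on an aromatic carbon, meta to a large group, gives no change at the digits printed from compound 2 to compound 4 (within the scatter) in this assay. Going by these compounds alone, this is the first direct reading of the change from 3-fluorophenyl to 3-chlorophenyl, and neither halogen gives this compound pair any measurable effect at the dose tested. Nothing available offers an explanation for this result.

Any difference between the two halogens too small to appear in this read-out stays hidden. On these data alone, whether a methoxy group or an amine on this same carbon would give a measurable effect remains open.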